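Oxime-oxygen substituent variation on the diaryl thioether series

The source may report more compounds than this note shows. Statements on the series, on what has been measured and on what is new or still open speak of the compounds shown alone.

Working notes. Two compounds have numbers in a functional assay (blood) for inhibition, with Homo sapiens as the target; a higher number here means a weaker inhibitor, a lower number a stronger inhibitor. Compound 2, `C/C(=N\OC(=O)C(C)(C)C)c1ccc(Sc2cc(F)cc(C3CCOCC3)c2)cc1`, gives 40 nM. Compound 1, `CO[C@]1(c2cc(F)cc(S(=O)(=O)c3ccc(/C(C)=N/O)cc3)c2)CCO[C@@H](C)C1`, gives 20 nM; compound 2 and compound 1 lie within the usual scatter of each other, so neither can be separated from the other. Going by the values given here, no measured pair here differs in a single place. Compound 3, `CCOC(=O)CO/N=C(\C)c1ccc(Sc2cc(F)cc(C3CCOCC3)c2)cc1`, is unmeasured; it differs from compound 2 by (ethoxycarbonyl)methyl in place of (tert-butyl)carbonyl on an oxygen. Among the compounds with values here, with no comparable measured pair to lean on, the expected step from compound 2 to compound 3 in this assay is no change at the digits printed from compound 2 to compound 3 (within the scatter), that is no change beyond the scatter. Compound 3 is therefore estimated at 40 nM, with a range of 15 nM to 120 nM.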

Compound 3, half-maximal inhibitory concentration: 610 nM
For compound 3 the middle estimate is 15-fold (1.18 log units) below the measured one; the whole stated range lies below it.
By their numbers in this assay, from the lowest: compounds 1 and 2 (each within the scatter of the next); then compound 3.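

On the oxygen whose other neighbour is the double-bonded nitrogen, the substituent is not a neutral choice in this assay: (ethoxycarbonyl)methyl in place of (tert-butyl)carbonyl gives a 15-fold higher number from compound 2 to compound 3 (1.18 log units; beyond the scatter). Both groups carry 6 heavy atoms, so heavy-atom count alone does not track this step. Nothing at hand bears on the reason for it.

Open, from the compounds shown here alone, is how a plain methyl, or a carboxylic acid in place of the ethyl ester, would read on this oxygen. Also open, going by these compounds, is whether the step carries over to the core of compound 1.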